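The source may hold more compounds than are shown below. What is called first, only, known or untested is meant among the compounds shown, and "the series" means these compounds.

Compound 1 `Cc1ccc(CCCN(CC[C@H](N)C(=O)O)C[C@H]2O[C@@H](n3cnc4c(N)ncnc43)[C@H](O)[C@@H]2O)cc1C(N)=O`: 51 nM
Compound 2 `NC(=O)c1cccc(CCCN(CCC[C@H](N)C(=O)O)C[C@H]2O[C@@H](n3cnc4c(N)ncnc43)[C@H](O)[C@@H]2O)c1`: 3000 nM

In an assay on cells for inhibition of Nicotinamide N-methyltransferase (Homo sapiens), read by fluorescence and coupled enzyme assay, with a stated time of 10 min, in the presence of a further agent that is not named here (a higher number here means a weaker inhibitor, a lower number a stronger inhibitor), compound 1 gives 51 nM, while compound 2 gives 3000 nM, the higher of the two numbers, a gap beyond the usual scatter. Compound 3 `Nc1ncnc2c1ncn2[C@@H]1O[C@H](CN(CCCc2ccc3ccccc3c2)CCC[C@H](N)C(=O)O)[C@@H](O)[C@H]1O` differs from compound 2 in one place: naphthalen-2-yl in place of 3-carbamoylphenyl on a saturated chain carbon, three bonds along the chain from an amine nitrogen. Among the compounds with values here, no measured pair isolates this change, so its effect is only estimated. A modest step toward a higher number is expected, a 2.7-fold higher number from compound 2 to compound 3 (0.43 log units; beyond the scatter). Compound 3 is therefore expected to give 8000 nM, within a range of 2000 nM to 30000 nM.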

Compound 3, inhibition constant: 33300 nM
For compound 3 the middle estimate is 4.2-fold (0.62 log units) below the measured one; measured number above the stated range.
By their numbers in this assay, from the lowest: compound 1; then compound 2; then compound 3.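

In this assay, naphthalen-2-yl in place of 3-carbamoylphenyl on this saturated chain carbon gives an 11-fold higher number from compound 2 to compound 3 (1.05 log units; beyond the scatter), so the number depends strongly on the group carried here. The change removes the carbamoyl group and adds a second aromatic ring, and this single step cannot separate those two parts. Nothing available explains the step.

From the compounds shown here alone, whether an unsubstituted phenyl or a 3-carboxyphenyl group would behave more like 3-carbamoylphenyl or naphthalen-2-yl remains open. So does whether the step would be as large with a shorter chain leading to the amino acid.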